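Furan to methylpyrimidine on a shared diarylaminopyrimidine core

The source may hold more compounds than are shown below. What is called first, only, known or untested is meant among the compounds shown, and "the series" means these compounds.

The two measured compounds share a core and were tested in a toxicity assay on MT4 cells (Homo sapiens) for cytotoxicity, read by MTT assay, with a stated time of 5 days; a higher number here means that more compound is tolerated, a lower number that less compound is tolerated. Compound 1, `Cc1cnc(Nc2ccc(C#N)cc2)nc1Nc1c(F)cc(-c2ccc(C#N)nc2)cc1F`, gives 62000 nM in this assay. Compound 2, `Cc1cc(-c2ccco2)cc(C)c1Nc1ccnc(Nc2ccc(C#N)cc2)n1`, gives 1700 nM in this assay. Going by the values given here, compound 2 therefore holds the lowest of the two numbers, the less tolerated one; the only neighbour is compound 1, whose number is higher by a gap that lies beyond the scatter. Nothing else is known that would tie the two to each other by a single change.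

Compound 3, `Cc1ncc(-c2cc(C)c(Nc3ccnc(Nc4ccc(C#N)cc4)n3)c(C)c2)cn1`, is not yet measured. It differs from compound 2 in one place: 2-methylpyrimidin-5-yl in place of furan-2-yl on an aromatic carbon. The change sits on an aromatic carbon of a six-membered aromatic ring of carbon only, meta to two methyl groups and para to a large group.

Among the compounds with values here, no step between measured compounds is available to guide the estimate. The account expects compound 3 to be tolerated somewhat better than compound 2, a step of a 2.4-fold higher number from compound 2 to compound 3 (0.37 log units; beyond the scatter) in this assay, modest in size and upward. Compound 3 is thus estimated at 4000 nM, within a range from 1500 nM to 12000 nM.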

Compound 3, half-maximal cytotoxic concentration: 3900 nM
Estimate against measurement, compound 3: 1.0-fold (0.01 log units) above; low and high end bracket the measured number.
By their numbers in this assay, from the lowest: compound 2; then compound 3; then compound 1.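

Going by these compounds alone, the step gives the first comparison that turns on a single place: in this assay, 2-methylpyrimidin-5-yl in place of furan-2-yl brings a 2.3-fold higher number from compound 2 to compound 3 (0.36 log units; beyond the scatter), modest in size but beyond the usual scatter. The aromatic carbon meta to two methyl groups and para to a large group is therefore not a silent position in this assay, since exchanging a five-membered aromatic ring with one hetero atom for a six-membered aromatic ring with two hetero atoms moves the number upward. No measurement shown here explains this shift, and the single step cannot separate the ring size, the hetero atoms and the methyl group from one another.

Going by these compounds, it remains open whether a plain phenyl ring, a morpholine or a carboxylic acid on this same carbon would carry the number further up or bring it back down. On these data alone, it is also open whether the same exchange would give a step of similar size on the core of compound 1, which differs from the other two compounds in more than one place.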